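Swapping the benzothiazole substituent on compound 2

This account rests on a few compounds, and the source may have more. Where it says the series, first, only, none or still open, it means among the compounds named here.

Compound 1 `COc1cc(CN(C(=O)CSc2nc3ccccc3s2)c2cc(OC)c(OC)c(OC)c2)cc(OC)c1OC` gives 65300 nM
Compound 2 `COc1ccc2nc(SCC(=O)N(Cc3ccc(OC)c(O)c3)c3cc(OC)c(OC)c(OC)c3)sc2c1` gives 352 nM

In a functional assay on HCT-116 cells (Homo sapiens) for antiproliferative activity, read by MTT assay, with a stated time of 48 h (on this read-out lower numbers stand for stronger inhibition and higher numbers for weaker inhibition), compound 2 at 352 nM holds the lower of the two numbers and compound 1 at 65300 nM the higher, a gap beyond the scatter. Compound 3 `COc1ccc(CN(C(=O)CSc2nc3c(C)cccc3s2)c2cc(OC)c(OC)c(OC)c2)cc1O` is still unmeasured. It carries 4-methyl-1,3-benzothiazol-2-yl in place of 6-methoxy-1,3-benzothiazol-2-yl on a sulfur, and the count of that change reads 4-methyl-1,3-benzothiazol-2-yl in place of 6-methoxy-1,3-benzothiazol-2-yl on a sulfur in full. Among the compounds with values here, no measured pair differs in one place only, so this expectation has little support. A moderate rise is expected in this assay from the starting point of compound 2 at 352 nM and that means weaker inhibition. The expected size is a 2.8-fold higher number from compound 2 to compound 3 (0.45 log units; beyond the scatter) as an estimate. Compound 3 is estimated at 1000 nM with an expected range from 200 nM to 6000 nM in this measurement.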

Compound 3, half-maximal inhibitory concentration: 852 nM
Compound 3: middle estimate off by 1.2-fold (0.07 log units), on the high side, within the range that was stated.
By their numbers in this assay, from the lowest: compound 2; then compound 3; then compound 1.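

In this assay, within the data shown here, the pair of compound 2 and compound 3 gives the first comparison that isolates the group on the sulfur. Putting 4-methyl-1,3-benzothiazol-2-yl in place of 6-methoxy-1,3-benzothiazol-2-yl produces a 2.4-fold higher number from compound 2 to compound 3 (0.38 log units; beyond the scatter) in a modest step, so this position accepts a change of substituent with only a limited shift, and compound 3 stays at 852 nM in the same range as its partner. No supporting measurement explains the direction of this step.

Since the methoxy group leaves and the methyl group enters in a single change, this one step cannot separate their contributions. The compounds shown also leave open how a 1,3-benzothiazol-2-yl carrying an amine or a carboxylic acid would read on that sulfur.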